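The compounds below may be only part of what the source reports. "The series", "measured", "known", "first", "only" and "open" are said of these compounds alone.

Values in a functional assay on A-375 cells (Homo sapiens) for activation, with a stated time of 3 days; a lower number here means that less compound is needed, a higher number that more compound is needed for the effect:
- compound 1 `O=C(Nc1ccc(-c2cscn2)cc1)C1CCCN(Cc2ccc(F)c(F)c2)C1`: 1240 nM
- compound 2 `O=C(NC1CCCN(Cc2ccc(F)c(F)c2)C1)c1ccc(-c2cscn2)cc1`: > 20000 nM (a limit, not a number)
- compound 3 `O=C(Nc1ccc(-c2cscn2)cc1)[C@@H]1CCCN(Cc2ccc(F)c(F)c2)C1`: 4000 nM

Compound 2 stands at > 20000 nM, which is a limit of the assay. Among the measured compounds shown here, of the two true numbers, compound 3 has the higher one, and compound 1 is its only numeric neighbour. Compound 4 `O=C(Nc1ccc(-c2cscn2)cc1)[C@H]1CCCN(Cc2ccc(F)c(F)c2)C1` is still to be measured: the two compounds have the same atoms and bonds and differ only in configuration as drawn: 1 of 1 stereo elements differ; a stereocentre at a saturated ring carbon is drawn R in compound 3 and S in compound 4.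

The measured step that bears on this change is a 3.2-fold higher number from compound 1 to compound 3 (0.51 log units; beyond the scatter), and it comes with the fact that one of compounds 1 and 3 is drawn with a defined configuration and the other without, at the place where they differ. The stereocentre is drawn without a configuration in compound 1. If that sample holds both configurations, the rise seen in a 3.2-fold higher number from compound 1 to compound 3 (0.51 log units; beyond the scatter) suggests that the S form accounts for more of its effect than the R form. A step to a lower number, beyond the scatter and somewhat larger than the measured one, is therefore expected in this assay. The expected step is a 5.3-fold lower number from compound 3 to compound 4 (0.73 log units; beyond the scatter). For compound 4 the estimated value is 750 nM, with an expected range of 300 nM to 2000 nM.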

Compound 4, half-maximal effective concentration: 270 nM
The estimate for compound 4 lay 2.8-fold (0.44 log units) above the measured number; the measured number lies below the stated range.
By their numbers in this assay, from the lowest: compound 4; then compound 1; then compound 3. At a limit, above all of these: compound 2.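

In this assay, inverting the stereocentre at the saturated ring carbon from R to S gives a 15-fold lower number from compound 3 to compound 4 (1.17 log units; beyond the scatter), and no other change accompanies it: the fact that compounds 3 and 4 differ only in the configuration as drawn. Compound 1, drawn without a configuration at this carbon, falls between the two defined forms, with a 4.6-fold lower number from compound 1 to compound 4 (0.66 log units; beyond the scatter): the fact that one of compounds 1 and 4 is drawn with a defined configuration and the other without, at the place where they differ. Compound 4 therefore has the lowest number among the three compounds that share this amide orientation, and its steps to both of the others lie beyond the scatter.

From the compounds shown here alone, it remains open whether the S form keeps this advantage when the fluorines of the shared core give way to an amine or a carboxylic acid. The compounds shown also do not tell why the configuration at this carbon has so large an effect in this cellular read-out.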